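Swapping the Aryl Group on the Sulfonamide Nitrogen

The compounds below may be only part of what the source reports. "The series", "measured", "known", "first", "only" and "open" are said of these compounds alone.

Two compounds share a core in which a cyclic urea is attached to a benzenesulfonamide. Compound 1 `Cc1ccc(NS(=O)(=O)c2ccc(N3CCNC3=O)cc2)cc1C` carries a 3,4-dimethylphenyl group on the sulfonamide nitrogen; in a functional assay on HT-29 cells (Homo sapiens) for antiproliferative activity, read by sulforhodamine B assay, with a stated time of 48 h (a higher number here means a weaker inhibitor, a lower number a stronger inhibitor), compound 1 gives 230 nM. Compound 2 `O=C1NCCN1c1ccc(S(=O)(=O)Nc2ccc(Cl)cc2)cc1` carries 4-chlorophenyl instead, and in this assay compound 2 gives 220 nM, the lowest of the two numbers, with compound 1 sitting within the scatter of it. The step of a 1.0-fold lower number from compound 1 to compound 2 (0.02 log units; within the scatter) shows that exchanging one aryl group for another at this position changed little. Compound 3 `COc1cccc(NS(=O)(=O)c2ccc(N3CCNC3=O)cc2)c1` differs from compound 2 by the change (3-methoxyphenyl in place of 4-chlorophenyl on a sulfonamide nitrogen). Among the compounds with values here, the one measured step at this position lay within the scatter, so no movement beyond the scatter is expected in this assay for compound 3 either. The expected step is a 1.2-fold higher number from compound 2 to compound 3 (0.07 log units; within the scatter). Compound 3 is therefore estimated to give 260 nM, within 110 nM to 650 nM.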

Compound 3, half-maximal inhibitory concentration: 120 nM
Beside the measured number, compound 3's estimate is 2.2-fold (0.34 log units) above it, and the stated range covers the measured number.
By their numbers in this assay, from the lowest: compounds 3, 2 and 1 (each within the scatter of the next).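

With a third aryl group on the sulfonamide nitrogen, this position now carries a group with an oxygen atom, and in this assay the steps are a 1.8-fold lower number from compound 2 to compound 3 (0.26 log units; within the scatter) and a 1.9-fold lower number from compound 1 to compound 3 (0.28 log units; within the scatter). Both steps lie within the scatter, so 3-methoxyphenyl, 4-chlorophenyl and 3,4-dimethylphenyl cannot be told apart at this position, and the hydrogen-bond acceptor counted in 3-methoxyphenyl brings no readable movement. No measurement at hand offers an explanation for this result.

From the compounds shown here alone, it remains open whether a group of a different kind on this nitrogen, such as a phenyl ring carrying an amine or a carboxylic acid, or a longer alkyl chain in place of the ring, would give a step beyond the scatter. Going by these compounds, whether a change to the shared core would move the number further is also open.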